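A few compounds are considered here, and "the series" means these few. Any claim that something is new, unique, unknown or untested is made for them only; others in the source may bear on it.

Compound 1 `CCOc1ccc2c(c1)C=CN(C)C(=O)C2C`: >= 120 ug/mL
Compound 2 `CC1C(=O)N(C)C=Cc2cc(OCC(C)(C)O)ccc21`: >= 131 ug/mL

In a physicochemical assay for solubility (a lower number here means a less soluble compound, a higher number a more soluble compound), compound 1 gives >= 120 ug/mL, which is a limit of the assay and not a number. Compound 2 gives >= 131 ug/mL, which is also a limit. Compound 3 `CCOc1ccc2c(c1)C(c1cc[nH]n1)=CN(C)C(=O)C2C` keeps the core of compound 1 but places 1H-pyrazol-3-yl in place of hydrogen on a double-bonded ring carbon.

Going by the values given here, only one measured step exists, a step that the two limits leave unreadable from compound 1 to compound 2. It involves a different change, 1-hydroxy-1-methylethyl in place of methyl, and gives no size to carry over. The forecast is therefore a cautious judgement, not a transfer from measured data. The expected step of an at least 1.7-fold lower number from compound 1 to compound 3 (0.23 log units; that floor lies within the scatter) points downward, with wide uncertainty and a real chance of another limit. The estimated value for compound 3 is 70 ug/mL, with an expected range of 15 ug/mL to 150 ug/mL.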

Compound 3, solubility: >= 99 ug/mL
Compound 3 was reported as a limit (the forecaster's own chance of this, stated with the estimate: 30%); middle value at least 1.4-fold (0.15 log units) from the limit.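

In this assay compound 3 gives >= 99 ug/mL, which is a limit, and compound 1 also gave only a limit, so the step from compound 1 to compound 3 cannot be read. On these data alone, whether compound 1, compound 2 and compound 3 really differ in this assay, and by how much, stays open.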